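The source may hold more compounds than are shown below. What is called first, only, known or untested is meant among the compounds shown, and "the series" means these compounds.

In a functional assay on KB-VIN10 cells (Homo sapiens) for inhibition, with a stated time of 72 h (on this read-out higher numbers stand for weaker inhibition and lower numbers for stronger inhibition), compound 1 `COc1ccc(S(=O)(=O)N2CCc3cccc(-c4ccc(N)cc4)c32)cc1` gives 262 nM and stands highest of the two numbers; compound 2 `COc1ccc(S(=O)(=O)N2CCc3cccc(-c4cccnc4)c32)cc1` gives 84.5 nM, reached by a 3.1-fold lower number from compound 1 to compound 2 (0.49 log units; beyond the scatter). Compound 3 `COc1ccc(S(=O)(=O)N2CCc3cccc(-c4ccc(O)cc4)c32)cc1` carries hydroxy in place of amino on an aromatic carbon. Within the data shown here, no measured step covers this change, since the single step between compound 1 and compound 2 exchanges the whole aryl group rather than its substituent. Compound 3 is therefore expected to show no step beyond the scatter, estimated as a 1.0-fold lower number from compound 1 to compound 3 (0.02 log units; within the scatter). The value of compound 3 in this assay is estimated at 250 nM, within 100 nM to 620 nM.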

Compound 3, half-maximal inhibitory concentration: 123 nM
The estimate for compound 3 lay 2.0-fold (0.31 log units) above the measured number, within the range that was stated.
By their numbers in this assay, from the lowest: compounds 2 and 3 (each within the scatter of the next); then compound 1.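

In this assay, hydroxy in place of amino on the aromatic carbon para to a large group gives a 2.1-fold lower number from compound 1 to compound 3 (0.33 log units; beyond the scatter) and so shows that a single-atom change within the substituent, not only exchange of the whole aryl group, moves the number. 4-Hydroxyphenyl in place of pyridin-3-yl gives a 1.5-fold higher number from compound 2 to compound 3 (0.16 log units; within the scatter), so these two groups cannot be told apart here. Nothing available explains the change from amino to hydroxy. Open, going by these compounds, is how a methoxy group or a carboxylic acid would read at this place, and how an unsubstituted phenyl ring would compare.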